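A few compounds are considered here, and "the series" means these few. Any claim that something is new, unique, unknown or untested is made for them only; others in the source may bear on it.

Compounds measured so far in a functional assay on A549 cells (Homo sapiens) for antiproliferative activity, read by XTT assay, with a stated time of 72 h; on this read-out higher numbers stand for weaker inhibition and lower numbers for stronger inhibition:
- compound 1 `COc1ccc(-c2cc3ccccc3nc2/C=C/C(=O)c2ccccc2)cc1` gives 7410 nM
- compound 2 `COc1ccc(-c2cc3ccccc3nc2/C=C/C(=O)c2ccc(O)cc2)cc1` gives 7440 nM
- compound 3 `COc1ccc(-c2cc3ccccc3nc2/C=C/C(=O)c2ccc(Br)s2)cc1` gives 6250 nM

Compound 3 holds the lowest of the three numbers, yet its gaps to the other two lie within the scatter, so no order among them can be claimed. Compound 4 `COc1ccc(-c2cc3ccccc3nc2/C=C/C(=O)c2c[nH]c3ccccc23)cc1` arises from compound 3 by the change (1H-indol-3-yl in place of 5-bromothiophen-2-yl on a carbonyl carbon). Two earlier steps altered the same carbonyl-bound group: a 1.2-fold lower number from compound 1 to compound 3 (0.07 log units; within the scatter) and a 1.2-fold lower number from compound 2 to compound 3 (0.08 log units; within the scatter), both within the scatter. On that basis compound 4 is expected to show no step beyond the scatter in this assay, with the estimated change being a 1.1-fold lower number from compound 3 to compound 4 (0.06 log units; within the scatter). Compound 4 is thus estimated at 5500 nM, within a range from 2500 nM to 12000 nM.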

Compound 4, half-maximal inhibitory concentration: > 10000 nM
Compound 4 ended at the assay's limit; the forecaster's own chance of this, stated with the estimate: 5%; middle value at least 1.8-fold (0.25 log units) away from the limit.
By their numbers in this assay, from the lowest: compounds 3, 1 and 2 (each within the scatter of the next). At a limit, above all of these: compound 4.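

Compound 4 is the only one of the four to reach a limit in this assay, and this reading is not a number: the limit of > 10000 nM in this assay, at which 1 of the 4 values shown sits. The steps give floors only: an at least 1.6-fold higher number from compound 3 to compound 4 (0.20 log units; that floor lies within the scatter), an at least 1.3-fold higher number from compound 2 to compound 4 (0.12 log units; that floor lies within the scatter) and an at least 1.3-fold higher number from compound 1 to compound 4 (0.13 log units; that floor lies within the scatter). Phenyl, 4-hydroxyphenyl and 5-bromothiophen-2-yl on the carbonyl carbon gave values within the scatter of one another, whereas 1H-indol-3-yl is the one group here whose value passes out of the measured range, though its true distance from them stays unknown.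

Open, on these data alone, is whether 1-methyl-1H-indol-3-yl or 4-aminophenyl on the carbonyl carbon would read as a number alongside compound 1, compound 2 and compound 3, or reach the limit as compound 4 does.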